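Carboxy in Place of Trifluoromethyl: What to Expect for Compound 4

The source may hold more compounds than are shown below. What is called first, only, known or untested is meant among the compounds shown, and "the series" means these compounds.

Of the compounds shown here, three built on one shared core have been measured in an assay on isolated protein for inhibition of 2-Hydroxyacid oxidase 2 (Homo sapiens), tested at 1 uM; on this read-out lower numbers stand for a weaker effect and higher numbers for a stronger effect at the one concentration tested. Compound 1 `Cc1n[nH]c(C(=O)O)c1Cc1cccc(-c2ccc(OC(F)(F)F)cc2)c1` gives 6%, compound 2 `Cc1n[nH]c(C(=O)O)c1Cc1cccc(-c2ccc(C(N)=O)cc2)c1` gives 18%, and compound 3 `Cc1n[nH]c(C(=O)O)c1Cc1cccc(-c2ccc(C(F)(F)F)cc2)c1` gives 8%. Compound 3 stands second highest of the three numbers, but both of its steps lie within the scatter: a number 2 percentage points higher from compound 1 to compound 3 (within the scatter), and a number 10 percentage points lower from compound 2 to compound 3 (within the scatter). Compound 4 `Cc1n[nH]c(C(=O)O)c1Cc1cccc(-c2ccc(C(=O)O)cc2)c1` differs from compound 3 by carboxy in place of trifluoromethyl on an aromatic carbon. The step that bears most on this change is a number 12 percentage points higher from compound 1 to compound 2 (beyond the scatter), where carbamoyl entered, together with the small reverse gap a number 10 percentage points lower from compound 2 to compound 3 (within the scatter). A modest rise is therefore expected, and the step for compound 4 is estimated as a number 8 percentage points higher from compound 3 to compound 4 (within the scatter). Compound 4 is thus estimated at 16%, with a range from 4% to 30%.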

Compound 4, a percentage reported as inhibition, at one concentration (the size of the read-out at that concentration, not a potency): 3%
For compound 4 the middle estimate is 13 percentage points above the measured one; the measured number lies below the stated range.
By their numbers in this assay, from the lowest: compounds 4, 1, 3 and 2 (each within the scatter of the next, the first and the last beyond it).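

In this assay, the carboxy group at this place, para to a large group, does not keep the level of the carbamoyl compound: hydroxy in place of amino on the carbonyl carbon gives a number 15 percentage points lower from compound 2 to compound 4 (beyond the scatter). Against the two fluorine-bearing groups, the change gives a number 5 percentage points lower from compound 3 to compound 4 (within the scatter) and a number 3 percentage points lower from compound 1 to compound 4 (within the scatter), so a carbonyl alone does not set compound 2 apart from the others. Nothing measured here explains this difference. As far as these compounds go, what remains open is whether a nitrile or a sulfonamide at this place would reach the number of compound 2, or whether carbamoyl stands alone.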